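Branching the Butyl Chain: From Compound 2 to Compound 3

The source may hold more compounds than are shown below. What is called first, only, known or untested is meant among the compounds shown, and "the series" means these compounds.

Compound 1 `Cc1ccc(CN2CCC(C(=O)Nc3ccc(CNc4nc(N(C)C)nc5cc(C)ccc45)cc3)CC2)cc1` reaches in a functional assay on SV5A8 cells (Homo sapiens) for cytotoxicity (a higher number here means a weaker inhibitor, a lower number a stronger inhibitor), only a limit, > 4150 nM.
Compound 2 `CCCCN1CCC(C(=O)Nc2ccc(CNc3nc(N(C)C)nc4cc(C)ccc34)cc2)CC1` reaches in this assay only a limit, > 10500 nM.

Compound 2 thus stands at a limit in this assay, as the limit of > 10500 nM in this assay, at which 1 of the 2 values shown sits, states, and compound 1 likewise, as the limit of > 4150 nM in this assay, at which 1 of the 2 values shown sits, states. Going by the values given here, the step that the two limits leave unreadable from compound 1 to compound 2 is therefore unreadable, and no measured step bears on the change to compound 3 `Cc1ccc2c(NCc3ccc(NC(=O)C4CCN(CC(C)C)CC4)cc3)nc(N(C)C)nc2c1`, which is isopropyl in place of propyl on a saturated chain carbon bound to an amine nitrogen in a ring. With both shown values at limits, compound 3 is expected to remain at a limit, and the step that the limit leaves unreadable from compound 2 to compound 3 is expected to be unreadable as well. Compound 3 is estimated at 15000 nM in this assay, within 5000 nM to 50000 nM.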

Compound 3, half-maximal inhibitory concentration: > 10500 nM
Compound 3: a limit, no number (the forecaster's own chance of this, stated with the estimate: 85%); the middle value lies beyond the limit too.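

In this assay compound 3 gives > 10500 nM, a limit and not a number, so the steps to compound 3 from compound 1 and compound 2 cannot be read. The compounds shown leave open whether propyl, isopropyl or 4-methylphenyl at this place changes the value at all.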